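Replacing the aryl amide with a pivaloyl group in a DAT series

This account rests on a few compounds, and the source may have more. Where it says the series, first, only, none or still open, it means among the compounds named here.

Compound 1 `[O-][S+](CCNC1CCN(Cc2ccc(F)cc2)CC1)C(c1ccc(F)cc1)c1ccc(F)cc1`: 50.6 nM
Compound 2 `[O-][S+](CCNC1CCN(CC(O)Cc2ccccc2)CC1)C(c1ccc(F)cc1)c1ccc(F)cc1`: 91.8 nM
Compound 3 `O=C(c1ccc(F)cc1)N1CCC(NCC[S+]([O-])C(c2ccc(F)cc2)c2ccc(F)cc2)CC1`: 77.2 nM

Of the compounds shown here, three sharing the same core have been measured in an assay on membranes from striatum (strain Sprague-Dawley) for displacement of a labelled ligand from sodium-dependent dopamine transporter (Rattus norvegicus), read by scintillation counting, with a stated time of 120 min; a lower number here means a stronger inhibitor, a higher number a weaker inhibitor. Compound 1 gives 50.6 nM in this assay, compound 2 gives 91.8 nM and compound 3 gives 77.2 nM. Compound 3 sits second highest of the three numbers, but its neighbours are close: a 1.2-fold lower number from compound 2 to compound 3 (0.08 log units; within the scatter) and a 1.5-fold higher number from compound 1 to compound 3 (0.18 log units; within the scatter), so the three values cannot be ordered with confidence.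

Compound 4 `CC(C)(C)C(=O)N1CCC(NCC[S+]([O-])C(c2ccc(F)cc2)c2ccc(F)cc2)CC1` has not yet been measured. It differs from compound 3 by tert-butyl in place of 4-fluorophenyl on a carbonyl carbon. For the measured compounds named here, none of the measured steps exchanges an aromatic ring for a branched alkyl group at this carbonyl carbon, so no step bears directly on the change. What the series does show is that every variation tried on the ring nitrogen has stayed within the scatter: a 1.8-fold higher number from compound 1 to compound 2 (0.26 log units; within the scatter), a 1.5-fold higher number from compound 1 to compound 3 (0.18 log units; within the scatter) and a 1.2-fold lower number from compound 2 to compound 3 (0.08 log units; within the scatter). On that basis a step of similar size is expected for a 1.4-fold higher number from compound 3 to compound 4 (0.15 log units; within the scatter), with no confident direction beyond the scatter. Compound 4 is therefore estimated at 110 nM in this assay, within a range of 45 nM to 270 nM.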

Compound 4, inhibition constant: 10200 nM
The estimate for compound 4 lay 93-fold (1.97 log units) below the measured number; the measured number lies above the stated range.
By their numbers in this assay, from the lowest: compounds 1, 3 and 2 (each within the scatter of the next); then compound 4.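

In this assay, the steps among compounds 1, 2 and 3 had all stayed within the scatter, which made the group on the ring nitrogen look open to wide variation, but this position proves far less forgiving: a 130-fold higher number from compound 3 to compound 4 (2.12 log units; beyond the scatter). With the carbonyl and the amide-type nitrogen kept, tert-butyl in place of 4-fluorophenyl on a carbonyl carbon is enough on its own to produce a step of this size. Compound 4 also stands apart from the other two, with a 110-fold higher number from compound 2 to compound 4 (2.05 log units; beyond the scatter) and a 200-fold higher number from compound 1 to compound 4 (2.30 log units; beyond the scatter), and among these four compounds it is the only one whose group on the ring nitrogen carries no aromatic ring.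

No measurement shown gives a cause for this step.

The compounds shown leave open whether the loss follows from removing the aromatic ring or from the tert-butyl group itself, as the 4-fluorophenyl and tert-butyl groups differ in both respects. A cyclohexyl group or an unbranched butyl chain on the same carbonyl carbon would help to separate the two, and an unsubstituted phenyl group would show what the fluorine contributes.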